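Swapping Cyclohexyl for Propylsulfanyl in a Sodium/Hydrogen Exchanger Series

The source may report more compounds than this note shows. Statements on the series, on what has been measured and on what is new or still open speak of the compounds shown alone.

Compound 1, `Cc1cc(F)c(S(C)(=O)=O)cc1C(=O)N=C(N)N`: 44 nM
Compound 2, `CS(=O)(=O)c1cc(C(=O)N=C(N)N)c(F)cc1F`: 630 nM
Compound 3, `Cc1cc(C2CCCCC2)c(S(C)(=O)=O)cc1C(=O)N=C(N)N`: 22 nM

All three compounds were tested in a functional assay for inhibition of sodium/hydrogen exchanger (Oryctolagus cuniculus); a lower number here means a stronger inhibitor, a higher number a weaker inhibitor. Compound 3 carries the lowest number of the three, although the gap to compound 1 lies within the scatter, so the two cannot be told apart on these data. The number for compound 2 is clearly higher: the step of a 14-fold higher number from compound 1 to compound 2 (1.16 log units; beyond the scatter), which comes from fluoro in place of methyl on an aromatic carbon, lies well beyond the scatter. The other measured step, a 2.0-fold lower number from compound 1 to compound 3 (0.30 log units; within the scatter), comes from cyclohexyl in place of fluoro on an aromatic carbon and stays within the scatter.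

Compound 4, `CCCSc1cc(C)c(C(=O)N=C(N)N)cc1S(C)(=O)=O`, has not yet been measured. It differs from compound 3 in one place: propylsulfanyl in place of cyclohexyl on an aromatic carbon. Among the compounds with values here, the only measured step at this same place is a 2.0-fold lower number from compound 1 to compound 3 (0.30 log units; within the scatter), and it remained within the scatter although the two groups there have little in common. On that basis no step beyond the scatter is expected for a 1.4-fold higher number from compound 3 to compound 4 (0.13 log units; within the scatter). Compound 4 is therefore expected to give about 30 nM, with a range from 12 nM to 80 nM.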

Compound 4, half-maximal inhibitory concentration: 6.8 nM
Estimate against measurement, compound 4: 4.4-fold (0.64 log units) above; measured number below the stated range.
By their numbers in this assay, from the lowest: compound 4; then compounds 3 and 1 (each within the scatter of the next); then compound 2.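

Within the data shown here, this position does respond to the group placed on it: in this assay, propylsulfanyl in place of cyclohexyl gives a 3.2-fold lower number from compound 3 to compound 4 (0.51 log units; beyond the scatter) and is the first step at this place to lie beyond the scatter. Propylsulfanyl in place of fluoro gives a 6.5-fold lower number from compound 1 to compound 4 (0.81 log units; beyond the scatter) and shows that compound 4 stands apart from both compounds that differ from it only here, although compound 1 and compound 3 themselves cannot be told apart. The entering group has fewer heavy atoms than cyclohexyl, has no ring, and brings a sulfur atom and one hydrogen-bond acceptor, but no measurement available here shows which of these differences, if any, accounts for the lower number.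

The compounds shown leave open whether the lower number goes with the sulfur atom or with the open chain, a question that a butyl or propoxy group at this place could help to settle. They also leave open how chain length matters, as with ethylsulfanyl or butylsulfanyl, and how an amine at this place would compare.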